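From a limit to a 3,5-difluorophenyl sulfonamide

This account rests on a few compounds, and the source may have more. Where it says the series, first, only, none or still open, it means among the compounds named here.

Measured in a functional assay on cells (leukaemia cell line, Homo sapiens) for inhibition, read by sulforhodamine B assay, with a stated time of 48 h (on this read-out higher numbers stand for weaker inhibition of growth and lower numbers for stronger inhibition of growth), so far:
- compound 1 `O=S(=O)(Nc1ccc(Cl)c(Cl)c1)c1ccc(-c2cnc(C3CC3)o2)cc1` gives 62100 nM as a number
- compound 2 `Cc1cc(NS(=O)(=O)c2ccc(-c3cnc(C4CC4)o3)cc2)ccc1Cl` gives 33400 nM as a number
- compound 3 `O=S(=O)(Nc1cc(Cl)ccc1Cl)c1ccc(-c2cnc(C3CC3)o2)cc1` gives > 100000 nM as a limit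

Compound 3 stands at > 100000 nM and this is a limit of this assay, not a number. Compound 4 `O=S(=O)(Nc1cc(F)cc(F)c1)c1ccc(-c2cnc(C3CC3)o2)cc1` has 3,5-difluorophenyl in place of 2,5-dichlorophenyl on a sulfonamide nitrogen with the core unchanged. Two measured steps bring in the group that compound 4 gives up, namely an at least 1.6-fold higher number from compound 1 to compound 3 (0.20 log units; that floor lies within the scatter) and an at least 2.9-fold higher number from compound 2 to compound 3 (0.47 log units; beyond the scatter), and only the second of these clears the scatter. The other step, a 1.9-fold lower number from compound 1 to compound 2 (0.27 log units; within the scatter), shows no change beyond the scatter. Among the measured compounds shown here, no measured compound carries fluorine, so this reading is an indirect one. Taking those two steps in reverse, a modest move to a lower number is expected, though a second limit remains possible. The expected change is an at least 1.6-fold lower number from compound 3 to compound 4 (0.22 log units; that floor lies within the scatter), an estimate resting on a limit. For compound 4 the estimated value is 60000 nM in this assay, with an expected range from 25000 nM to 100000 nM at the ends.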

Compound 4, concentration for total growth inhibition: 80000 nM
The estimate for compound 4 lay 1.3-fold (0.12 log units) below the measured number; the range from low to high includes it.
By their numbers in this assay, from the lowest: compounds 2, 1 and 4 (each within the scatter of the next, the first and the last beyond it). At a limit, above all of these: compound 3.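

Replacing 2,5-dichlorophenyl with 3,5-difluorophenyl on a sulfonamide nitrogen turns a limit into a number in this assay, a change read as an at least 1.2-fold lower number from compound 3 to compound 4 (0.09 log units; that floor lies within the scatter). Set against other groups at this place, 3,5-difluorophenyl gives a 2.4-fold higher number from compound 2 to compound 4 (0.38 log units; beyond the scatter), a modest loss against 4-chloro-3-methylphenyl, but a 1.3-fold higher number from compound 1 to compound 4 (0.11 log units; within the scatter), which marks no real difference from 3,4-dichlorophenyl. Compound 3 remains a limit and not a number, so the full size of its step cannot be known: the limit of > 100000 nM in this assay, at which 1 of the 4 values shown sits.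

The compounds shown leave open whether the kind of halogen or its placing on the ring matters more, since the changes here alter both at once. Going by these compounds, how an amine or a methoxy group on this ring would behave also remains open.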